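Aryl piperazine amides on a shared core: HL-60 growth inhibition

The source may hold more compounds than are shown below. What is called first, only, known or untested is meant among the compounds shown, and "the series" means these compounds.

Measured so far:
compound 1, `Cc1nc(-c2ccccc2)c(C(=O)N2CCN(c3cccc(C)c3C)CC2)o1`: 35 nM
compound 2, `COc1ccc(-c2nc(C)oc2C(=O)N2CCN(c3cccc(Cl)c3)CC2)cc1`: "not active" (no number reported)

Within the data shown here, in a functional assay on HL-60 cells (Homo sapiens) for inhibition, read by MTT assay, with a stated time of 72 h (a lower number here means a stronger inhibitor, a higher number a weaker inhibitor), compound 1 gives 35 nM, the only number in the set. Among the measured compounds shown here, compound 2 is reported as "not active" (no number reported) with no number, and it differs from compound 1 in more than one place, so no single step can be drawn from the pair.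

Compound 3, `Cc1ccc(N2CCN(C(=O)c3oc(C)nc3-c3ccccc3)CC2)cc1`, is not yet measured. It differs from compound 1 by 4-methylphenyl in place of 2,3-dimethylphenyl on an amine nitrogen in a ring. For the measured compounds named here, with no measured step to lean on, a modest loss beyond the scatter is expected, a 2.3-fold higher number from compound 1 to compound 3 (0.36 log units; beyond the scatter). Compound 3 is estimated at 80 nM, within 25 nM to 300 nM.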

Compound 3, half-maximal inhibitory concentration: > 1000 nM
Compound 3 ended at the assay's limit; the forecaster's own chance of this, stated with the estimate: 15%; middle value at least 12-fold (1.09 log units) away from the limit.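

In this assay, compound 3 gives > 1000 nM, which is a limit of the assay and not a number. Among these compounds, on the amine nitrogen in the ring, 4-methylphenyl in place of 2,3-dimethylphenyl gives an at least 28-fold higher number from compound 1 to compound 3 (1.45 log units; beyond the scatter), the first readable step, showing that activity in this pair depends strongly on the phenyl substitution. The upper size of this step remains unknown: the limit of > 1000 nM in this assay, at which 1 of the 3 values shown sits.

The pair does not separate the loss of one methyl from the change in methyl placement. On these data alone, how a plain phenyl or a phenyl bearing a carboxylic acid would read on this nitrogen remains open.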